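The source may hold more compounds than are shown below. What is called first, only, known or untested is meant among the compounds shown, and "the series" means these compounds.

Working notes on the selenium and sulfur series.

Three compounds carry numbers. Compound 1 `CS/C(=N\C(=O)c1sccc1Cl)NC(=O)c1sccc1Cl` in a functional assay on K562 cells (Homo sapiens) for cytotoxicity, read by MTT assay, with a stated time of 72 h (on this read-out higher numbers stand for weaker inhibition of growth and lower numbers for stronger inhibition of growth), gives 78900 nM. Compound 3 `O=C(/N=C(/NC(=O)c1cccs1)[Se]Cc1ccccc1)c1cccs1` in this assay gives 58500 nM. Compound 2 `C[Se]/C(=N\C(=O)c1ccco1)NC(=O)c1ccco1` in this assay gives > 100000 nM, which is a limit of the measurement and not a number; compound 2 therefore stands at the limit of > 100000 nM in this assay, at which 1 of the 3 values shown sits, the only one of the three to do so. Going by the values given here, of the two numbered compounds, compound 1 and compound 3 sit close together on this read-out, and no step between any pair of the measured compounds is worked out here.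

The compound still to be measured is compound 4 `O=C(/N=C(/NC(=O)c1ccco1)[Se]Cc1ccccc1)c1ccco1`. It differs from compound 2 by phenyl in place of hydrogen on a saturated chain carbon bound to a selenium atom; in the wider cut the change reads methyl to benzyl at the selenium. Compound 3 also carries benzyl on selenium and returns a number, while compound 2 with methyl on selenium returns only a limit, so the move from compound 2 to compound 4 is expected to bring the value down out of the limit into a region similar to compound 3, with an at least 1.4-fold lower number from compound 2 to compound 4 (0.15 log units; that floor lies within the scatter) as the expected step. For compound 4 the estimate in this assay is 70000 nM, with a range from 35000 nM to 150000 nM.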

Compound 4, concentration for total growth inhibition: 44200 nM
Compound 4: the middle estimate sits 1.6-fold (0.20 log units) above what was measured; measured number inside the range.
By their numbers in this assay, from the lowest: compounds 4, 3 and 1 (each within the scatter of the next). At a limit, above all of these: compound 2.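

Going by these compounds alone, this position responds to change: in this assay, methyl to benzyl at the selenium gives an at least 2.2-fold lower number from compound 2 to compound 4 (0.35 log units; beyond the scatter), the only step so far between compounds that differ in one place. The value of compound 2 is a limit and not a number, so the step has a floor and no upper bound: the limit of > 100000 nM in this assay, at which 1 of the 4 values shown sits. Within the data shown here, the added phenyl, on a saturated chain carbon bound to a selenium atom, thus moves the compound from a limit onto the measurable part of the read-out, something the earlier compounds, with no such pair among them, could not show.

From the compounds shown here alone, the full size of this step remains open, as does whether the same change acts alike on the core of compound 1 or compound 3, since neither has a partner here that differs from it in one place. Also open, going by these compounds, is what a longer chain such as butyl at the selenium, or an amine or a carboxylic acid on the phenyl ring of the benzyl group, would do to the number.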